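The compounds below may be only part of what the source reports. "The series", "measured", "known", "first", "only" and "open" are said of these compounds alone.

Of the compounds shown here, two of a shared core have been tested so far in a functional assay on A-375 cells (Homo sapiens) for antiproliferative activity, read by CCK-8 assay, with a stated time of 72 h, tested at 8 uM; on this read-out higher numbers stand for a stronger effect at the one concentration tested and lower numbers for a weaker effect. Compound 1 `CN(C(=S)SCc1ccc(C(=O)Nc2ccccc2N)cc1)c1cccnc1` carries a methyl(pyridin-3-yl)amino group on its thiocarbonyl carbon, and in this assay compound 1 gives 87.7%. Compound 2 `COc1ccc(N2CCN(C(=S)SCc3ccc(C(=O)Nc4ccccc4N)cc3)CC2)cc1` carries a larger ring-bearing group at the same place, and in this assay compound 2 gives 35.9%. Compound 1 therefore holds the higher of the two numbers, and the gap to compound 2 lies beyond the usual scatter of repeated measurements.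

Compound 3 `Nc1ccccc1NC(=O)c1ccc(CSC(=S)N2CCc3cc(Cl)ccc32)cc1` has not yet been measured. It differs from compound 1 in one place: 5-chloro-2,3-dihydro-1H-indol-1-yl in place of methyl(pyridin-3-yl)amino on a thiocarbonyl carbon. For the measured compounds named here, nothing among the measured pairs shows what such a change does to the read-out, so only a cautious guess is possible. A step of moderate size downward, as the change from compound 1 to compound 3, is expected: a number 22.7 percentage points lower from compound 1 to compound 3 (beyond the scatter). In this assay compound 3 is estimated at 65%, with a plausible range from 30% to 92%.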

Compound 3, a percentage reported as inhibition, at one concentration (the size of the read-out at that concentration, not a potency): 82.3%
Beside the measured number, compound 3's estimate is 17.3 percentage points below it, within the range that was stated.
By their numbers in this assay, from the lowest: compound 2; then compounds 3 and 1 (each within the scatter of the next).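

In this assay, the exchange of the group on a thiocarbonyl carbon, with methyl(pyridin-3-yl)amino leaving and 5-chloro-2,3-dihydro-1H-indol-1-yl entering, gives a number 5.4 percentage points lower from compound 1 to compound 3 (within the scatter), so this pair cannot be told apart on this read-out. The earlier compounds shown here could not show that this position tolerates such a different group: the leaving group has a six-membered aromatic ring with a hetero atom and a hydrogen-bond acceptor, while the entering one has a five-membered non-aromatic ring, a six-membered aromatic ring of carbon only, a chlorine and no hydrogen-bond acceptor, so in this one pair the acceptor counted in the leaving group is not required to keep the read-out. No measurement here explains why the read-out holds across this change.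

The compounds shown leave open what the chlorine itself contributes, which the parent 2,3-dihydro-1H-indol-1-yl group without chlorine, or a version carrying bromine or a methoxy group instead, could help to settle. They also leave open how a small open-chain group such as dimethylamino would behave here, and whether this pair would still match in potency, since a reading at one concentration does not give one.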